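A few compounds are considered here, and "the series" means these few. Any claim that something is new, unique, unknown or untested is made for them only; others in the source may bear on it.

Measured so far:
- compound 1, `COc1cc(C)cc(-c2c(-c3ccnc(-c4ccc(C(C)=O)cc4)c3)cnn2CC#N)c1`: 83%
- compound 2, `COc1cc(C)cc(-c2nn(CC#N)cc2-c2ccnc(-c3ccc(N(C)C)cc3)c2)c1`: 97%

In a functional assay on OVCAR-8 cells (Homo sapiens) for cytotoxicity, read by sulforhodamine B assay, with a stated time of 48 h, tested at 0.01 uM (on this read-out higher numbers stand for a weaker effect at the one concentration tested and lower numbers for a stronger effect), compound 1 gives 83%, the lower of the two numbers; compound 2 gives 97%, a value beyond the scatter above it. Compound 3, `COc1cc(C)cc(-c2c(-c3ccnc(-c4ccc(N(C)C)cc4)c3)cnn2CC#N)c1`, has not been measured. It differs from compound 1 by dimethylamino in place of acetyl on an aromatic carbon. Because compound 2, which also carries the dimethylamino group, shows 97%, a step upward of modest size is expected, as a number 10 percentage points higher from compound 1 to compound 3 (within the scatter). For compound 3 the expected value in this assay is 93%, with a range from 82% to 102%.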

Compound 3, a percentage reported as activity, at one concentration (the size of the read-out at that concentration, not a potency): 28%
Beside the measured number, compound 3's estimate is 65 percentage points above it, and the stated range ends above it.
By their numbers in this assay, from the lowest: compound 3; then compound 1; then compound 2.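

In this assay, dimethylamino in place of acetyl on this aromatic carbon gives a number 55 percentage points lower from compound 1 to compound 3 (beyond the scatter), which means a stronger effect at the one concentration tested. The two groups each have 3 heavy atoms and no ring, yet they are far from interchangeable at this position, so the read-out depends strongly on which group sits here. Nothing available gives a reason for this step.

Going by these compounds, whether a smaller amine such as amino, or a ring amine such as morpholine, would keep this stronger effect remains open. So does whether the effect would hold at other concentrations.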